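From Methylphenyl to Chlorophenyl in a Weak Antagonist

The source may report more compounds than this note shows. Statements on the series, on what has been measured and on what is new or still open speak of the compounds shown alone.

Compound 1 `CC(C)c1cc(C(C)(C)C)cc(-c2cccc(C(F)(F)F)c2)c1CO` gives only an assay limit, > 50000 nM.
Compound 2 `CC(C)c1cc(C(C)(C)C)cc(-c2ccc(-c3ccccc3)cc2)c1CO` gives 680 nM.
Compound 3 `Cc1ccccc1CCC(=O)Nc1sc2c(c1C#N)CCCC2` gives 11000 nM.

In a functional assay on RKE cells for antagonist activity at Vasoactive intestinal polypeptide receptor 1 (Rattus norvegicus), read by HTRF and cAMP accumulation, with stated times of 10 min and 30 min (a lower number here means a stronger inhibitor, a higher number a weaker inhibitor), compound 3 holds the highest of the two numbers measured; its nearest neighbour, compound 2, sits at a lower number, a gap beyond the usual scatter. Compound 1 stands at the limit of > 50000 nM in this assay, at which 1 of the 3 values shown sits.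

Compound 4 `N#Cc1c(NC(=O)CCc2ccc(Cl)cc2)sc2c1CCCC2` has not yet been measured. It differs from compound 3 by 4-chlorophenyl in place of 2-methylphenyl on a saturated chain carbon, two bonds along the chain from a carbonyl carbon. No measured pair among these compounds changes in this way, so nothing shown fixes the direction. The step of a 1.4-fold lower number from compound 3 to compound 4 (0.14 log units; within the scatter) is expected to be small, possibly within the scatter, leaning slightly toward a lower number. Compound 4 is therefore estimated at 8000 nM, with a range from 3000 nM to 25000 nM.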

Compound 4, half-maximal inhibitory concentration: 1200 nM
Compound 4: middle estimate off by 6.7-fold (0.82 log units), on the high side, and the stated range ends above it.
By their numbers in this assay, from the lowest: compounds 2 and 4 (each within the scatter of the next); then compound 3. At a limit, above all of these: compound 1.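

In this assay, 4-chlorophenyl in place of 2-methylphenyl on a saturated chain carbon, two bonds along the chain from a carbonyl carbon, gives a 9.2-fold lower number from compound 3 to compound 4 (0.96 log units; beyond the scatter). Among these compounds, this is the first measured sign that this position responds to the aromatic group it carries, even though both groups have the same count of heavy atoms and neither has a hydrogen-bond donor or acceptor. Nothing measured here accounts for the step. This single step does not separate the arrival of the chlorine from the loss of the methyl group. Going by these compounds, how an unsubstituted phenyl or a pyridyl group on the same chain carbon would read remains open.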